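Cyano-bearing series: replacing the 2-oxopyrrolidin-1-yl group

The source may hold more compounds than are shown below. What is called first, only, known or untested is meant among the compounds shown, and "the series" means these compounds.

Measured in a functional assay for inhibition, with Sus scrofa as the target; on this read-out lower numbers stand for stronger inhibition and higher numbers for weaker inhibition:
compound 1 `CC1(C)C=C(n2ccccc2=O)c2cc(C#N)ccc2O1`: 50 nM
compound 2 `CC1=C(n2ccccc2=O)c2cc(C#N)ccc2OC1(C)C`: 5000 nM
compound 3 `CC1(C)Oc2ccc(C#N)cc2[C@@H](N2CCCC2=O)[C@]1(C)O`: 4000 nM

Not yet measured: compound 4 `CC1(C)Oc2ccc(C#N)cc2[C@@H](Oc2ccc(=O)[nH]n2)[C@]1(C)O`.

Compound 3, at 4000 nM, lies within the scatter of compound 2 at 5000 nM. Both numbers stand far above compound 1 at 50 nM, so compound 3 sits at the weak end of this small set.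

The next change is a group of 8 heavy atoms (4 carbon, 2 nitrogen, 2 oxygen; one six-membered aromatic ring with 2 hetero atoms) in place of a group of 6 heavy atoms (4 carbon, 1 nitrogen, 1 oxygen; one five-membered non-aromatic ring with 1 hetero atom), on a saturated ring carbon. It falls on a saturated ring carbon, next to the ring atom that bears a hydroxy group, and the rest of compound 3 stays as it is.

Going by the values given here, no measured step isolates this exchange. Among the compounds with values here, the only step on record is a 100-fold higher number from compound 1 to compound 2 (2.00 log units; beyond the scatter), a large one, but it concerns a methyl group on a double-bonded ring carbon and not the group exchanged here. It therefore gives only loose guidance on size. Compound 1 at 50 nM shows that much lower numbers occur in the series, though compound 1 lacks the methyl group that compound 4 retains. In this assay, a modest move towards a lower number is therefore expected, far smaller than the measured step. The estimated change is a 2.7-fold lower number from compound 3 to compound 4 (0.43 log units; beyond the scatter). For compound 4 the expected value is 1500 nM, with an estimated range of 200 nM to 8000 nM.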

Compound 4, half-maximal inhibitory concentration: 6 nM
Beside the measured number, compound 4's estimate is 250-fold (2.40 log units) above it, and the stated range ends above it.
By their numbers in this assay, from the lowest: compound 4; then compound 1; then compounds 3 and 2 (each within the scatter of the next).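

In this assay this saturated ring carbon, next to the ring atom that bears a hydroxy group, proves highly sensitive to the group it carries: exchanging 2-oxopyrrolidin-1-yl for the larger six-membered aromatic ring group gives a 670-fold lower number from compound 3 to compound 4 (2.82 log units; beyond the scatter), with the rest of the structure unchanged. The earlier step concerned only a methyl group on a double-bonded ring carbon, so this is the first measured change at this position, and with compound 4 at 6 nM the core shared by compound 3 and compound 4 is shown to be compatible with a very low number. Nothing available indicates which difference in the entering group accounts for the step, whether its ring size, its aromatic ring, its second ring hetero atom or its hydrogen-bond donor.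

These differences change together in a single exchange, so the two compounds cannot separate their contributions. Going by these compounds, it also remains open how this position would respond to a smaller group such as an amine, to a carboxylic acid or to a longer chain, and whether the entering group would have the same effect on the core of compound 1.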